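Brominated catechol alcohols: extending the hydroxymethyl to propoxymethyl

The source may report more compounds than this note shows. Statements on the series, on what has been measured and on what is new or still open speak of the compounds shown alone.

Measured compounds:
compound 1 `OCc1cc(O)c(O)c(Br)c1`, 51500 nM
compound 2 `OCc1cc(Br)c(O)c(O)c1Br`, 15000 nM
compound 3 `OCc1cc(O)c(O)c(Br)c1Br`, 18300 nM

In a functional assay on DLD-1 cells (Homo sapiens) for cytotoxicity, read by MTT assay, with a stated time of 96 h (on this read-out higher numbers stand for weaker inhibition and lower numbers for stronger inhibition), compound 1 gives 51500 nM. Adding a second bromo in place of hydrogen on an aromatic carbon lowers the number in both directions tried: a 3.4-fold lower number from compound 1 to compound 2 (0.54 log units; beyond the scatter) and a 2.8-fold lower number from compound 1 to compound 3 (0.45 log units; beyond the scatter). Compound 2 thus holds the lowest number of the three, though its gap to compound 3 lies within the scatter, so the two cannot be ordered.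

The step now followed leads from compound 2 to compound 4 `CCCOCc1cc(Br)c(O)c(O)c1Br`. The change is propyl in place of hydrogen on an oxygen on a saturated carbon, that is, hydroxymethyl to propoxymethyl. Neither measured step touches this part of the molecule; both concern bromo on the core, so nothing in the data shows how the alcohol oxygen responds to substitution. Within the data shown here, with no bearing step, the expected change is none beyond the scatter, and the uncertainty is correspondingly wide. Compound 4 is therefore estimated at 15000 nM in this assay, with a range from 5000 nM to 45000 nM. The step this estimate implies is expected to be no change at the digits printed from compound 2 to compound 4 (within the scatter).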

Compound 4, half-maximal inhibitory concentration: 1720 nM
Compound 4: the middle estimate sits 8.7-fold (0.94 log units) above what was measured; the whole stated range lies above it.
By their numbers in this assay, from the lowest: compound 4; then compounds 2 and 3 (each within the scatter of the next); then compound 1.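

Among these compounds, the earlier steps concerned only bromo on the shared core, so this is the first sign that the oxygen of the hydroxymethyl group responds to substitution: in this assay, propyl in place of hydrogen on that oxygen gives an 8.7-fold lower number from compound 2 to compound 4 (0.94 log units; beyond the scatter). The hydrogen on this oxygen is therefore not required to keep the number low in this pair, since replacing it with propyl lowers the number rather than raising it. Nothing available explains why the propoxymethyl compound gives the lower number.

With a single chain on this oxygen, the compounds shown leave open whether the effect depends on chain length, as a methyl, a butyl or a longer chain would show, or whether an amine in place of the oxygen would serve as well. They also leave open whether propoxymethyl would give a similar step on the bromo arrangement of compound 3.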